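The source may report more compounds than this note shows. Statements on the series, on what has been measured and on what is new or still open speak of the compounds shown alone.

Compound 1, `CC/C(=N\OC)c1ccccc1NCC1=NCCN1`, is tested in a functional assay for activation of Alpha-1A adrenergic receptor (Homo sapiens), read by calcium flux (on this read-out lower numbers stand for smaller maximal responses and higher numbers for larger maximal responses), and gives 112%. For the measured compounds named here, of the two compounds measured so far it stands highest, and its nearest neighbour is compound 2, `CO/N=C/c1ccccc1NCC1=NCCN1`, which in this assay gives 94%. Going by the values given here, the only step measured so far runs a number 18 percentage points lower from compound 1 to compound 2 (beyond the scatter), and it changes the atoms on the aromatic carbon, so it does not speak to the change considered here. Compound 3, `CC/C(=N/OC)c1ccccc1NCC1=NCCN1`, differs from compound 1 in this way: the two compounds have the same atoms and bonds and differ only in configuration as drawn: 1 of 1 stereo elements differ; a double bond is drawn E in compound 1 and Z in compound 3. Among the compounds with values here, no measured pair mirrors such a change of drawn configuration, so there is nothing to anchor the size or direction of the step; the expectation is a step of a number 12 percentage points lower from compound 1 to compound 3 (beyond the scatter), essentially within the usual scatter of this assay. For compound 3 the maximal response in this assay is therefore estimated at 100%, with a range from 75% to 125%.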

Compound 3, largest response reached (reported as maximum), in percent of the reference or control that the assay uses: 141%
Compound 3: middle estimate off by 41 percentage points, on the low side; the whole stated range lies below it.
By their numbers in this assay, from the lowest: compound 2; then compound 1; then compound 3.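

In this assay, the drawn geometry of a single double bond matters on its own, with no atom entering or leaving: the read-out runs a number 29 percentage points higher from compound 1 to compound 3 (beyond the scatter). The gap can be traced to that geometry alone because of what separates the pair: the fact that compounds 1 and 3 differ only in the configuration as drawn. The read-out also runs a number 47 percentage points higher from compound 2 to compound 3 (beyond the scatter), so, set beside the earlier step to compound 2, the group of 6 heavy atoms on the aromatic carbon cannot be judged by its atoms alone, as its two drawn forms give different numbers.

From the compounds shown here alone, it remains open whether a longer chain on the same double bond, or a benzyl group on its oxygen, would keep the higher number with the Z drawing. Also open, going by these compounds, is whether the group of 4 heavy atoms would answer a change of drawn configuration in the same direction.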